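A few compounds are considered here, and "the series" means these few. Any claim that something is new, unique, unknown or untested is made for them only; others in the source may bear on it.

Compound 1 `O=c1[nH]c(=O)n(CCC(CO)CO)cc1-c1ccco1` carries a furan-2-yl group on the shared core. In a functional assay on MCF7 cells (Homo sapiens) for antiproliferative activity, read by MTT assay, with a stated time of 72 h (a higher number here means a weaker inhibitor, a lower number a stronger inhibitor), compound 1 gives < 10 nM, which is a limit of the assay rather than a measured number. Compound 2 `CCCCCc1ccc(C#Cc2cn(CCC(COC(C)=O)COC(C)=O)c(=O)n(C(=O)c3ccccc3)c2=O)cc1` gives 100 nM in this assay. Compound 3 `CC(=O)OCC(CCn1cc(C#CC2CC2)c(=O)n(C(=O)c2ccccc2)c1=O)COC(C)=O` gives 100 nM in this assay. The step of no change at the digits printed from compound 2 to compound 3 (within the scatter) shows that exchanging one group on a triple-bonded carbon for another left the result within the scatter.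

Compound 4 `CC(C)(C)C#Cc1cn(CCC(CO)CO)c(=O)[nH]c1=O` differs from compound 1 in one place: 3,3-dimethylbut-1-yn-1-yl in place of furan-2-yl on an aromatic carbon. Within the data shown here, the only measured step involving a triple-bonded group is no change at the digits printed from compound 2 to compound 3 (within the scatter), and it was flat. Among the measured compounds shown here, no measured pair exchanges an aromatic ring for a triple-bonded chain, and no measured step joins the unprotected compound 1 to the protected compounds 2 and 3. On these data alone, compound 1 stands at the limit of < 10 nM in this assay, at which 1 of the 3 values shown sits, so how far it lies beyond that mark is unknown, and any step away from it cannot be sized from a limit. Compound 4 is therefore expected to give 30 nM in this assay, with a likely range from 5 nM to 300 nM. The step of an at least 3.0-fold higher number from compound 1 to compound 4 (0.47 log units; beyond the scatter) is expected to be a modest loss, if any.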

Compound 4, half-maximal inhibitory concentration: 95900 nM
Beside the measured number, compound 4's estimate is 3200-fold (3.50 log units) below it; the measured number lies above the stated range.
By their numbers in this assay, from the lowest: compounds 2 and 3 (each within the scatter of the next); then compound 4. At a limit, below all of these: compound 1.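

This position is far from indifferent to what it carries: in this assay, replacing the furan-2-yl group with 3,3-dimethylbut-1-yn-1-yl gives an at least 9500-fold higher number from compound 1 to compound 4 (3.98 log units; beyond the scatter). The earlier compounds shown here offered only the flat step no change at the digits printed from compound 2 to compound 3 (within the scatter), which exchanged one group at the far end of a triple bond for another, and the present result shows that this flatness does not extend to replacing a five-membered aromatic ring with a chain that has no ring and holds a triple bond. The printed step gives only the smallest size the change can have, as compound 1 is reported as a limit of the assay and not as a number: the limit of < 10 nM in this assay, at which 1 of the 4 values shown sits.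

This single exchange removes the ring and brings in the triple bond and the bulky carbon end together, so the compounds shown cannot say which of these changes accounts for the large step. A phenyl or thiophen-2-yl group at this position would test whether another aromatic ring keeps the result close to that of compound 1, while a simple ethyl or propyl chain would test whether the triple bond matters.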